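The source may hold more compounds than are shown below. What is called first, only, known or untested is meant among the compounds shown, and "the series" means these compounds.

Working notes on the series. Compound 3 `O=C1c2ccccc2N(Cc2cccc3ccccc23)S(=O)(=O)N1Cc1ccccc1` shares its core with compound 1 `Cc1ccc(CN2c3ccccc3C(=O)N(Cc3ccccc3)S2(=O)=O)cc1` and compound 2 `COc1ccc(CN2c3ccccc3C(=O)N(Cc3ccccc3)S2(=O)=O)cc1`; the three differ only in the group on the saturated chain carbon bound to the sulfonamide nitrogen in the ring. In a functional assay on MRC5 cells (Homo sapiens) (a higher number here means that more compound is tolerated, a lower number that less compound is tolerated), compound 1 gives 63000 nM. In this assay compound 2 gives 61000 nM. In this assay compound 3 gives > 58000 nM, which is a limit of the assay and not a number. For the measured compounds named here, compound 3 thus stands at the edge of what the numbers show: the steps into it, a step that the limit leaves unreadable from compound 1 to compound 3 and a step that the limit leaves unreadable from compound 2 to compound 3, cannot be read, and the only readable step in the set, a 1.0-fold lower number from compound 1 to compound 2 (0.01 log units; within the scatter), lies within the scatter. The single limit is recorded as the limit of > 58000 nM in this assay, at which 1 of the 3 values shown sits.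

Compound 4 `O=C1c2ccccc2N(Cc2cccnc2)S(=O)(=O)N1Cc1ccccc1` is the next member: pyridin-3-yl in place of naphthalen-1-yl on a saturated chain carbon bound to a sulfonamide nitrogen in a ring. Going by the values given here, no measured step bears directly on this exchange; the one readable step changes a small substituent on the same aryl group, and the two steps that exchange the whole aryl group end at a limit. For compound 4 the expectation is therefore no step beyond the scatter, with a step that the limit leaves unreadable from compound 3 to compound 4 placed about the values of the other members. In this assay compound 4 is estimated at 60000 nM, with a range from 30000 nM to 120000 nM. A report of only a limit for compound 4 remains a real possibility.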

Compound 4, half-maximal cytotoxic concentration: 66000 nM
The estimate for compound 4 lay 1.1-fold (0.04 log units) below the measured number; the measured number falls inside the stated range.
By their numbers in this assay, from the lowest: compounds 2, 1 and 4 (each within the scatter of the next).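

In this assay, exchanging the whole aryl group on a saturated chain carbon bound to a sulfonamide nitrogen in a ring now gives readable steps: a 1.1-fold higher number from compound 2 to compound 4 (0.03 log units; within the scatter) and a 1.0-fold higher number from compound 1 to compound 4 (0.02 log units; within the scatter) both lie within the scatter. Pyridin-3-yl, with one hetero atom in its ring and one hydrogen-bond acceptor, is therefore not told apart from 4-methoxyphenyl or 4-methylphenyl at this position, so the flat picture no longer rests only on the small substituent change on the aryl group. All steps involving compound 3 still cannot be read, because its value is a limit of the assay and not a number: the limit of > 58000 nM in this assay, at which 1 of the 4 values shown sits.

As far as these compounds go, whether naphthalen-1-yl truly differs from the three other groups stays open, as does what a group of another kind, such as an amine or a carboxylic acid, would do in place of the aryl group on this chain carbon. From the compounds shown here alone, all four compounds share the rest of the structure, so the effect of a change elsewhere on the shared core also remains open.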